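The compounds below may be only part of what the source reports. "The series", "measured", "known", "first", "only" and "open" are said of these compounds alone.

Working notes on the series. In an assay on blood for inhibition of Indoleamine 2,3-dioxygenase 1 (Homo sapiens) (on this read-out higher numbers stand for weaker inhibition and lower numbers for stronger inhibition), compound 1 `O=C(Nc1ccc(Cl)cc1)C1(c2ccc3c(c2)CCN3c2ccccn2)CCC1` gives 640 nM, and compound 2 `Cc1nccc(N2CCc3nc(C4(C(=O)Nc5ccc(F)cc5)CCC4)ccc32)n1` gives 430 nM; the two numbers sit within the scatter of each other, so neither stands apart. Compound 3 `O=C(c1cccc(Cl)c1)N1CCc2nc(C3(C(=O)Nc4ccc(F)cc4)CCC3)ccc21` is not yet measured. It differs from compound 2 in one place: (3-chlorophenyl)carbonyl in place of 2-methylpyrimidin-4-yl on a nitrogen on an aromatic ring in a ring. Among the compounds with values here, no measured pair shows the effect of such a change, so nothing from the measured compounds fixes its size. The step from compound 2 to compound 3 in this assay is expected to be small, a 1.9-fold higher number from compound 2 to compound 3 (0.27 log units; within the scatter), with direction uncertain. Compound 3 is therefore estimated at 800 nM, in the range 250 nM to 2500 nM.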

Compound 3, half-maximal inhibitory concentration: 93 nM
The estimate for compound 3 lay 8.6-fold (0.93 log units) above the measured number; the whole stated range lies above it.
By their numbers in this assay, from the lowest: compound 3; then compounds 2 and 1 (each within the scatter of the next).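

On a nitrogen of the five-membered non-aromatic ring, (3-chlorophenyl)carbonyl in place of 2-methylpyrimidin-4-yl gives a 4.6-fold lower number from compound 2 to compound 3 (0.66 log units; beyond the scatter) in this assay. This position therefore responds to the group it carries, which compound 1 and compound 2 could not show, since they differ in more than one place. No measurement shown here accounts for the step.

Whether the carbonyl or the 3-chlorophenyl ring matters more remains open, with only one carbonyl-linked group shown at this nitrogen. Unsubstituted benzoyl or acetyl in the same place would separate the two parts.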